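The source may report more compounds than this note shows. Statements on the series, on what has been measured and on what is new or still open speak of the compounds shown alone.

Notes on the series. Compound 1 `Nc1nc(Cl)c2ncn(C3CC(CO)C(O)C3O)c2n1` and compound 2 `Nc1nc(O)c2ncn(C3CC(CO)C(O)C3O)c2n1` share the same core and differ by a hydroxy in place of a chloro on an aromatic carbon. In a functional assay on cells (Cancer cell lines, Homo sapiens) for cytotoxicity (on this read-out lower numbers stand for an effect already at smaller amounts and higher numbers for an effect only at larger amounts of compound), compound 1 gives > 100 ug/mL, which is a limit of the assay and not a number. In this assay compound 2 gives > 100 ug/mL, again a limit and not a number. The step that the two limits leave unreadable from compound 1 to compound 2 is therefore of unreadable size. Compound 2 stands on a limit only, and both values shown sit at the limit of > 100 ug/mL in this assay, at which 2 of the 2 values shown sit; no measured number places it within the working range of this assay.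

Compound 3 `Nc1nc(S)c2ncn(C3CC(CO)C(O)C3O)c2n1` is the next member. It differs from compound 2 by sulfanyl in place of hydroxy on an aromatic carbon. For the measured compounds named here, the only measured step bears on this change solely in that both of its ends are limits, so it gives no readable size. Nothing measured thus points to a change beyond the scatter in this assay, and a further limit is the most likely outcome. The step of a number no higher from compound 2 to compound 3 (the limit leaves the size open) is accordingly expected to be small. For compound 3 the estimate in this assay is 100 ug/mL, with a range from 30 ug/mL to 300 ug/mL.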

Compound 3, concentration for half-maximal effect: 50 ug/mL
Estimate against measurement, compound 3: 2.0-fold (0.30 log units) above; measured number inside the range.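

With sulfanyl on this aromatic carbon, next to the ring nitrogen, compound 3 supplies the only value among the three compounds that is a number rather than a limit in this assay, while the chloro and hydroxy compounds give no such number: the limit of > 100 ug/mL in this assay, at which 2 of the 3 values shown sit.

Against the hydroxy compound the change reads as an at least 2.0-fold lower number from compound 2 to compound 3 (0.30 log units; that floor lies within the scatter), and against the chloro compound it reads as an at least 2.0-fold lower number from compound 1 to compound 3 (0.30 log units; that floor lies within the scatter). Both sizes are floors, so this position can carry a group that gives a measurable read-out, but the data do not establish a change beyond the scatter, and the step between compound 1 and compound 2 cannot be read.

As far as these compounds go, how far compound 1 and compound 2 lie past their limits remains open, and with it the true size of both steps and any order between the chloro and hydroxy groups. Also open, from the compounds shown here alone, is whether the read-out at this position would follow sulfur further, as with a methylsulfanyl group or a longer thioether chain, or whether an amine in the same place would give a number as well.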